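Demethylation of the methoxy group in the bis(trifluoromethyl) urea

The source may report more compounds than this note shows. Statements on the series, on what has been measured and on what is new or still open speak of the compounds shown alone.

Compound 1 `O=C(Nc1cccc(-n2cc(-c3ccncc3)c(-c3ccc(Cl)c(O)c3)n2)c1)Nc1cccc(C(F)(F)F)c1`: in a functional assay on SW-620 cells (Homo sapiens) for inhibition, read by sulforhodamine B assay, with a stated time of 48 h (a higher number here means a weaker inhibitor of growth, a lower number a stronger inhibitor of growth), compound 1 gives > 32500 nM, which is a limit of the assay and not a number.
Compound 2 `COc1cc(-c2nn(-c3cccc(NC(=O)Nc4cc(C(F)(F)F)cc(C(F)(F)F)c4)c3)cc2-c2ccncc2)ccc1Cl`: in this assay compound 2 gives 1860 nM.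
Compound 3 `COc1cc(-c2nn(-c3cccc(NC(=O)Nc4cccc(C(F)(F)F)c4)c3)cc2-c2ccncc2)ccc1Cl`: in this assay compound 3 gives 14300 nM.

Of the two numbers shown, compound 2 is the lower; the nearest number sits a 7.7-fold higher number from compound 2 to compound 3 (0.89 log units; beyond the scatter). The third value is only a limit and cannot be ranked against these.

Compound 4 `O=C(Nc1cccc(-n2cc(-c3ccncc3)c(-c3ccc(Cl)c(O)c3)n2)c1)Nc1cc(C(F)(F)F)cc(C(F)(F)F)c1` differs from compound 2 by hydrogen in place of methyl on an oxygen on an aromatic ring. Within the data shown here, one measured step touches the same oxygen, but in the opposite direction: an at least 2.2-fold lower number from compound 1 to compound 3 (0.35 log units; beyond the scatter). Its size is known only as a bound, since compound 1 sits at the limit of > 32500 nM in this assay, at which 1 of the 3 values shown sits. Running the change backwards, removal of the methyl is expected to raise the number in this assay by a modest amount or more, in the step of a 4.0-fold higher number from compound 2 to compound 4 (0.61 log units; beyond the scatter). Compound 4 is therefore estimated at 7500 nM, with a range from 2500 nM to 30000 nM; a limit read-out for compound 4 is possible but not expected.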

Compound 4, concentration for total growth inhibition: 5110 nM
For compound 4 the middle estimate is 1.5-fold (0.17 log units) above the measured one, within the range that was stated.
By their numbers in this assay, from the lowest: compound 2; then compound 4; then compound 3. At a limit, above all of these: compound 1.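

In this assay, hydrogen in place of methyl on the oxygen now has a step with two measured ends, a 2.7-fold higher number from compound 2 to compound 4 (0.44 log units; beyond the scatter), and it runs the same way as the earlier bound on the other core: the same change on two cores in this assay, an at least 2.2-fold lower number (0.35 log units; beyond the scatter) from compound 1 to compound 3 and a 2.7-fold lower number (0.44 log units; beyond the scatter) from compound 4 to compound 2; the limit leaves it open whether they differ

Trifluoromethyl in place of hydrogen on an aromatic carbon also lowers the number when the ring carries hydroxy rather than methoxy, an at least 6.3-fold lower number from compound 1 to compound 4 (0.80 log units; beyond the scatter), so this change too is now seen on two cores: the same change on two cores in this assay, a 7.7-fold higher number (0.89 log units; beyond the scatter) from compound 2 to compound 3 and an at least 6.3-fold higher number (0.80 log units; beyond the scatter) from compound 4 to compound 1; the limit leaves it open whether they differ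

The value of compound 1, > 32500 nM, is a limit of the assay, so that step is a bound.

The compounds shown leave open whether either change has the same size on both cores. Also open, from the compounds shown here alone, is how an amine or an ethoxy group in place of the methoxy would read.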